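Amide Aryl Replacement: From Compound 2 to Compound 3

This account rests on a few compounds, and the source may have more. Where it says the series, first, only, none or still open, it means among the compounds named here.

Compound 1 `Cc1cc(C(=O)Nc2cccc(-c3oc4cc(-c5ccc(F)cc5)ccc4c(=O)c3O)c2)ccc1F`: 7440 nM
Compound 2 `Cc1cc(C)cc(C(=O)Nc2cccc(-c3oc4cc(-c5ccc(F)cc5)ccc4c(=O)c3O)c2)c1`: 11900 nM

In a functional assay on MDA-MB-231 cells (Homo sapiens) for antiproliferative activity, read by CCK-8 assay, with a stated time of 72 h (a lower number here means a stronger inhibitor, a higher number a weaker inhibitor), compound 1 gives 7440 nM and compound 2 gives 11900 nM. Among the compounds with values here, compound 2 holds the higher of the two numbers, yet the only measured step, a 1.6-fold higher number from compound 1 to compound 2 (0.20 log units; within the scatter), lies within the scatter, so the two compounds are not separated. Compound 3 `O=C(Nc1cccc(-c2oc3cc(-c4ccc(F)cc4)ccc3c(=O)c2O)c1)c1ccc(Cl)nc1` differs from compound 2 by 6-chloropyridin-3-yl in place of 3,5-dimethylphenyl on a carbonyl carbon. Within the data shown here, the one step that bears on this, an aryl exchange at the same carbonyl carbon, was within the scatter, so compound 3 is expected to show no change beyond the scatter: a 1.2-fold lower number from compound 2 to compound 3 (0.08 log units; within the scatter). Compound 3 is estimated at 10000 nM, between 4000 nM and 25000 nM.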

Compound 3, half-maximal inhibitory concentration: 1760 nM
Compound 3: middle estimate off by 5.7-fold (0.75 log units), on the high side; the whole stated range lies above it.
By their numbers in this assay, from the lowest: compound 3; then compounds 1 and 2 (each within the scatter of the next).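

The aryl group on this carbonyl carbon can move the number beyond the scatter: in this assay the 6-chloropyridin-3-yl group gives a 6.8-fold lower number from compound 2 to compound 3 (0.83 log units; beyond the scatter) and a 4.2-fold lower number from compound 1 to compound 3 (0.63 log units; beyond the scatter), whereas the exchange between the two carbon-only aryl rings did not separate compound 1 and compound 2. Both steps are modest, yet compound 3 now stands apart from the other two compounds. No measurement shown here explains this drop. The compounds leave open whether the ring nitrogen or the chlorine alone would give it, and how a 6-aminopyridin-3-yl or 6-methoxypyridin-3-yl group would read on the same carbonyl carbon.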